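Series notes: methoxy in place of hydrogen, compound 3

The source may hold more compounds than are shown below. What is called first, only, known or untested is meant among the compounds shown, and "the series" means these compounds.

Measured compounds and their values in a functional assay on HCC 2998 cells (Homo sapiens) for inhibition; on this read-out higher numbers stand for weaker inhibition of growth and lower numbers for stronger inhibition of growth:
compound 1 `O=C(/C=C/c1cccc(O)c1)c1cccc(-n2cc(-c3ccccc3)[nH]c2=O)c1` gives 4090 nM
compound 2 `COc1cc(/C=C/C(=O)c2cccc(-n3cc(-c4ccccc4)[nH]c3=O)c2)cc(OC)c1OC` gives 1260 nM

Compound 2 stands lowest of the two numbers in this assay. The nearest number belongs to compound 1, which sits higher by a gap that is beyond the usual scatter of this read-out, so compound 2 is the stronger growth inhibitor of the two. Among the compounds with values here, no pair of measured compounds differs in one place only, so no single step is documented so far.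

Compound 3 `COc1ccc(-c2cn(-c3cccc(C(=O)/C=C/c4cc(OC)c(OC)c(OC)c4)c3)c(=O)[nH]2)cc1` is not yet measured. It differs from compound 2 by methoxy in place of hydrogen on an aromatic carbon. Within the data shown here, nothing among the measured compounds shows the effect of this particular change, so the expected step cannot be read from a documented pair. The change is small in size and the working expectation is a step not beyond the scatter, with no firm direction.

The expected step of a 1.1-fold lower number from compound 2 to compound 3 (0.06 log units; within the scatter) is therefore estimated as small. For compound 3 the expected value in this assay is 1100 nM, within a range from 400 nM to 3200 nM.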

Compound 3, concentration for 50% growth inhibition: 1640 nM
Beside the measured number, compound 3's estimate is 1.5-fold (0.17 log units) below it; the measured number falls inside the stated range.
By their numbers in this assay, from the lowest: compounds 2 and 3 (each within the scatter of the next); then compound 1.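

In this assay, within the data shown here, the change from phenyl to 4-methoxyphenyl gives a 1.3-fold higher number from compound 2 to compound 3 (0.11 log units; within the scatter) and is the first single-place step documented. The numbers of compound 2 and compound 3 cannot be told apart, so in this one pair, methoxy in place of hydrogen on this aromatic carbon, para to a large group, gives no step beyond the scatter. Nothing available bears on why this substitution gives such a small step.

Still open, going by these compounds, is whether another group at this same carbon, such as an amine, a carboxylic acid or a longer chain like butoxy, would give a step beyond the scatter, as one methoxy example says little about the position as a whole. On these data alone, it is also open whether the same phenyl to 4-methoxyphenyl change would give a similarly small step when made on compound 1 with its value of 4090 nM as the starting point, since the present step rests on the background of compound 2 alone.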